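Sulfonyl aryl swap: methyl for chloro, compound 4

The source may hold more compounds than are shown below. What is called first, only, known or untested is meant among the compounds shown, and "the series" means these compounds.

Three measured compounds share one core and differ at the aryl on the sulfonyl sulfur and at the core substituent. In an assay on isolated protein for displacement of a labelled ligand from metabotropic glutamate receptor 5 (Homo sapiens), with a stated time of 60 min, tested at 1 uM (a lower number here means less inhibition, a higher number more inhibition at the concentration tested (going by the name of the read-out)), compound 1 `COc1ccc2ncc(S(=O)(=O)c3ccc(C)cc3)c(N3CCC(C)CC3)c2c1` gives 90%, compound 2 `Cc1ccc2ncc(S(=O)(=O)c3ccc(F)c(Cl)c3)c(N3CCC(C)CC3)c2c1` gives 93%, and compound 3 `Cc1ccc2ncc(S(=O)(=O)c3ccc(Cl)cc3)c(N3CCC(C)CC3)c2c1` gives 79%. Among the compounds with values here, the only single-site step measured is a number 14 percentage points lower from compound 2 to compound 3 (beyond the scatter). Compound 3 stands lowest of the three, beyond the scatter from both others. Compound 4 `Cc1ccc(S(=O)(=O)c2cnc3ccc(C)cc3c2N2CCC(C)CC2)cc1` differs from compound 3 by methyl in place of chloro on an aromatic carbon. Within the data shown here, no measured step covers this exact change; the step from compound 2 to compound 3 is the only measured change at the sulfonyl aryl and was modest, while compound 1, also carrying 4-methylphenyl on the sulfonyl sulfur, gives 90%. A small rise is therefore expected for compound 4, a number 6 percentage points higher from compound 3 to compound 4 (within the scatter). Compound 4 is estimated at 85%, range 72% to 95%.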

Compound 4, a percentage reported as inhibition, at one concentration (the size of the read-out at that concentration, not a potency): 82%
Estimate against measurement, compound 4: 3 percentage points above, within the range that was stated.
By their numbers in this assay, from the lowest: compounds 3, 4, 1 and 2 (each within the scatter of the next, the first and the last beyond it).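

In this assay, 4-methylphenyl in place of 4-chlorophenyl on the sulfonyl sulfur gives a number 3 percentage points higher from compound 3 to compound 4 (within the scatter), so this swap does not separate the two groups. Set against the 3-chloro-4-fluorophenyl group, the 4-methylphenyl group gives a number 11 percentage points lower from compound 2 to compound 4 (beyond the scatter), a step of the same kind as a number 14 percentage points lower from compound 2 to compound 3 (beyond the scatter). On the core, methyl in place of methoxy gives a number 8 percentage points lower from compound 1 to compound 4 (within the scatter), so that change is not resolved either.

No measurement at hand explains any of these steps. On these data alone, how an amine or a carboxylic acid on the sulfonyl aryl, or a longer chain in place of the core methyl, would read remains open.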